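Methoxy Replaces Hydrogen on an Aryl Ring of Compound 1

The source may report more compounds than this note shows. Statements on the series, on what has been measured and on what is new or still open speak of the compounds shown alone.

Compound 1 `c1ccc(C2=NN(c3ccc(-c4ccccc4)nn3)C(c3ccccc3)C2)cc1` is the unsubstituted member of this small set. In a functional assay on A549 cells (Homo sapiens) for antiproliferative activity, read by MTT assay, with a stated time of 24 h (a lower number here means a stronger inhibitor, a higher number a weaker inhibitor), compound 1 gives > 100000 nM, which is a limit of the assay rather than a number (the limit of > 100000 nM in this assay, at which 1 of the 3 values shown sits). Two relatives built on the same core were measured as numbers in this assay. Compound 2 `FC(F)(F)c1ccc(C2CC(c3ccccc3)=NN2c2ccc(-c3ccccc3)nn2)cc1` gives 9160 nM in this assay, and compound 3 `COc1ccc(C2CC(c3ccccc3)=NN2c2ccc(-c3ccccc3)nn2)c(OC)c1` gives 9560 nM. The change of trifluoromethyl in place of hydrogen on an aromatic carbon gave an at least 10-fold lower number from compound 1 to compound 2 (1.03 log units; beyond the scatter), and the change of 2,4-dimethoxyphenyl in place of phenyl on a saturated ring carbon gave an at least 10-fold lower number from compound 1 to compound 3 (1.01 log units; beyond the scatter); comparing the two substituted compounds, a 1.0-fold higher number from compound 2 to compound 3 (0.02 log units; within the scatter).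

Compound 4 `COc1ccc(C2=NN(c3ccc(-c4ccccc4)nn3)C(c3ccccc3)C2)cc1` differs from compound 1 by methoxy in place of hydrogen on an aromatic carbon. Both measured steps from compound 1 placed a substituent on an aryl group of the core and each lowered the number by a large amount, while the kind of substituent made no difference beyond the scatter. The step to compound 4 is of the same sort, so a large downward step is expected in this assay, although it is uncertain whether the new number will fall below the limit at all. The estimate for compound 4 is 20000 nM, with a range from 6000 nM to 100000 nM, meaning an expected step of an at least 5.0-fold lower number from compound 1 to compound 4 (0.69 log units; beyond the scatter).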

Compound 4, half-maximal inhibitory concentration: 75900 nM
For compound 4 the middle estimate is 3.8-fold (0.58 log units) below the measured one, within the range that was stated.
By their numbers in this assay, from the lowest: compounds 2 and 3 (each within the scatter of the next); then compound 4. At a limit, above all of these: compound 1.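

In this assay, the change from phenyl to 4-methoxyphenyl gives an at least 1.3-fold lower number from compound 1 to compound 4 (0.11 log units; that floor lies within the scatter), and it places the substituent on a different phenyl from the one on a saturated ring carbon that carries the changes in compound 2 and compound 3. Compound 4 therefore shows that a measured number can also be reached with a methoxy on this other phenyl, para to a large group, but unlike the steps to compound 2 and compound 3, this step has a floor that does not by itself establish a change beyond the scatter. The value of compound 1 is a limit, so the true size of the step cannot be read: the limit of > 100000 nM in this assay, at which 1 of the 4 values shown sits.

The compounds shown leave open whether trifluoromethyl at this same place would give a number close to that of compound 4, and whether a hydroxyl, an amine or a carboxylic acid there would move the number further in either direction. They also leave open how methoxy would behave at the other carbons of this phenyl, and whether a longer chain such as ethoxy would be tolerated in its place.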